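A few compounds are considered here, and "the series" means these few. Any claim that something is new, unique, unknown or untested is made for them only; others in the source may bear on it.

Working notes on the series: in an in vitro ADME assay on microsomes from liver (Simiiformes) (on this read-out higher numbers stand for a longer-lived compound and lower numbers for a shorter-lived compound), compound 1 `Cc1cc(CCCOc2c(C)cc(-c3noc(C)n3)cc2C)on1` gives 0.45 h, while compound 2 `Cc1cc(CCCOc2c(C)cc(-c3noc(C(N)=O)n3)cc2C)on1` gives 2.3 h, the highest of the two numbers. Compound 3 `CCOc1nc(-c2cc(C)c(OCCCc3cc(C)no3)c(C)c2)no1` has ethoxy in place of carbamoyl on an aromatic carbon. Ethoxy has not been measured at this place, so the only guide is the modest rise a 5.1-fold higher number from compound 1 to compound 2 (0.71 log units; beyond the scatter), which lies beyond the scatter. Compound 3 lacks the carbamoyl of compound 2, so most of that rise should be lost. The estimated change, lower and of similar size, is a 3.3-fold lower number from compound 2 to compound 3 (0.52 log units; beyond the scatter). For compound 3 the expected value in this assay is 0.7 h, with an estimated range of 0.25 h to 1.8 h.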

Compound 3, half-life: > 2.5 h
Compound 3 was reported as a limit (the forecaster's own chance of this, stated with the estimate: 3%); at least 3.5-fold (0.55 log units) between middle value and limit.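

Compound 3 is reported only as a limit in this assay: the limit of > 2.5 h in this assay, at which 1 of the 3 values shown sits. At this aromatic carbon, the carbamoyl is therefore not required for the gain over methyl, since ethoxy, with 0 hydrogen-bond donors, also gives an at least 5.5-fold higher number from compound 1 to compound 3 (0.74 log units; beyond the scatter). Against carbamoyl, the step reads an at least 1.0-fold higher number from compound 2 to compound 3 (0.03 log units; that floor lies within the scatter), so the order of compound 2 and compound 3 cannot be settled.

As far as these compounds go, how far compound 3 lies past its limit remains open. So does whether an amine or a longer alkoxy chain such as butoxy would keep the gain at this place.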